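A Flat Series Meets a 2-Fluorophenyl Swap

The source may report more compounds than this note shows. Statements on the series, on what has been measured and on what is new or still open speak of the compounds shown alone.

In a physicochemical assay, with a stated time of 30 min (a higher number here means a weaker inhibitor, a lower number a stronger inhibitor), compound 2 `C/C(=N\N=C1/SCC(=O)N1Cc1cccc(Cl)c1)c1cccs1` gives 20300000 nM and sits within the scatter of both its measured neighbours. Compound 1 `C/C(=N\N=C1/SCC(=O)N1Cc1cccc(F)c1)c1cccs1` gives 21100000 nM and compound 3 `C/C(=N\N=C1/SCC(=O)N1Cc1cccc(Cl)c1)c1ccccn1` gives 26800000 nM in the same series.

Compound 4 `C/C(=N\N=C1/SCC(=O)N1Cc1ccccc1F)c1cccs1` has not yet been measured. It carries 2-fluorophenyl in place of 3-chlorophenyl on a saturated chain carbon bound to an amide-type nitrogen in a ring.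

For the measured compounds named here, two measured steps bear on this change. Chloro in place of fluoro on an aromatic carbon gives a 1.0-fold lower number from compound 1 to compound 2 (0.02 log units; within the scatter) and stays within the scatter. Pyridin-2-yl in place of thiophen-2-yl gives a 1.3-fold higher number from compound 2 to compound 3 (0.12 log units; within the scatter) and also stays within the scatter. Going by the values given here, no measured compound carries the 2-fluorophenyl group, so these small steps are only indirect evidence. No shift beyond the scatter is expected in this assay and no firm direction can be named.

The expected step is a 1.1-fold higher number from compound 2 to compound 4 (0.03 log units; within the scatter) and it stays within the scatter. Compound 4 is estimated at 22000000 nM (expected range 12000000 nM to 38000000 nM).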

Compound 4, half-maximal inhibitory concentration: 15700000 nM
Estimate against measurement, compound 4: 1.4-fold (0.15 log units) above; measured number inside the range.
By their numbers in this assay, from the lowest: compounds 4, 2, 1 and 3 (each within the scatter of the next).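

In this assay, 2-fluorophenyl at this place, on a saturated chain carbon bound to an amide-type nitrogen in a ring, stays within the scatter of 3-chlorophenyl (a 1.3-fold lower number from compound 2 to compound 4 (0.11 log units; within the scatter)) and of 3-fluorophenyl (a 1.3-fold lower number from compound 1 to compound 4 (0.13 log units; within the scatter)). The earlier compounds shown here compared only 3-fluorophenyl with 3-chlorophenyl, so the flat picture at this place now extends to a third group, and to a different halogen placement on the phenyl ring. Nothing given here accounts for this flatness.

The compounds shown leave open whether a group without a halogen, such as an unsubstituted phenyl, or a phenyl carrying an amine or a carboxylic acid, would also stay within the scatter at this place. They also leave open whether any change here can move the number beyond the scatter.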